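The source may report more compounds than this note shows. Statements on the series, on what has been measured and on what is new or still open speak of the compounds shown alone.

Compound 1, `O=S(=O)(/C=C/c1ccc(O)c(O)c1)CC1CCC1`, is the parent of this comparison. In a functional assay, read by fluorescence and spectrophotometry, with a stated time of 1 h (a lower number here means that less compound is needed, a higher number that more compound is needed for the effect), compound 1 gives 8800 nM, the second highest of the three numbers shown. Its nearest neighbour is compound 2, `O=S(=O)(/C=C/c1ccc(O)c(O)c1)CC1CCCO1`, which in this assay gives 10500 nM, a step of a 1.2-fold higher number from compound 1 to compound 2 (0.08 log units; within the scatter). Compound 3, `C=CCCCCCS(=O)(=O)/C=C/c1ccc(O)c(O)c1`, gives 7100 nM, a step of a 1.2-fold lower number from compound 1 to compound 3 (0.09 log units; within the scatter); between the two the step is a 1.5-fold lower number from compound 2 to compound 3 (0.17 log units; within the scatter). Compound 4, `O=S(=O)(/C=C/c1ccc(O)c(O)c1)CC1CCCC1`, differs from compound 1 by cyclopentyl in place of cyclobutyl on a saturated chain carbon bound to a sulfonyl sulfur. The three steps that bear on this change all sit at the same place and all fall inside the scatter, so no step beyond the scatter is expected; compound 4 is estimated at 8500 nM, between 4500 nM and 17000 nM, a step of a 1.0-fold lower number from compound 1 to compound 4 (0.02 log units; within the scatter).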

Compound 4, half-maximal effective concentration: 9400 nM
Compound 4: middle estimate off by 1.1-fold (0.04 log units), on the low side, and the stated range covers the measured number.
By their numbers in this assay, from the lowest: compounds 3, 1, 4 and 2 (each within the scatter of the next).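

In this assay, cyclopentyl in place of cyclobutyl on a saturated chain carbon bound to a sulfonyl sulfur gives a 1.1-fold higher number from compound 1 to compound 4 (0.03 log units; within the scatter), and the comparisons with the other two groups give a 1.3-fold higher number from compound 3 to compound 4 (0.12 log units; within the scatter) and a 1.1-fold lower number from compound 2 to compound 4 (0.05 log units; within the scatter). Across these four compounds, a further carbon ring at this place therefore adds no step beyond the scatter. Nothing shown bears on the reason for this. Going by these compounds, whether an amine, a carboxylic acid or a longer saturated chain at this place would give a step beyond the scatter remains open, as does the effect of any change elsewhere on the shared core.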